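A few compounds are considered here, and "the series" means these few. Any claim that something is new, unique, unknown or untested is made for them only; others in the source may bear on it.

The shared core carries two aromatic rings, and the two measured compounds differ only in one of them. Compound 1, `COc1ccc(-c2c(C#N)c(N)c(C#N)c(SC)c2-c2ccccc2)cc1`, has a hydrogen on that ring, while compound 2, `COc1ccc(-c2c(C#N)c(N)c(C#N)c(SC)c2-c2ccc(OC)cc2)cc1`, carries a methoxy there. In an assay on isolated protein for inhibition of Maltase-glucoamylase (Homo sapiens), tested at 100 uM (on this read-out higher numbers stand for more inhibition at the one concentration tested (going by the name of the read-out) and lower numbers for less inhibition), compound 1 gives 5.7%, and in this assay compound 2 gives 14.4%. That is a change of a number 8.7 percentage points higher from compound 1 to compound 2 (within the scatter), so compound 2 sits highest of the two numbers, but within the scatter of compound 1.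

Compound 3, `COc1ccc(-c2c(C#N)c(N)c(C#N)c(SC)c2-c2ccc(F)cc2)cc1`, is the next step from compound 2: fluoro in place of methoxy on an aromatic carbon. For the measured compounds named here, the only measured step that speaks to the same ring, from compound 1 to compound 2, stayed within the scatter, and nothing measured so far shows a fluoro at this place. A step of a number 4.4 percentage points lower from compound 2 to compound 3 (within the scatter) is therefore expected, that is, none beyond the scatter. Compound 3 is estimated at 10%, with a range from 0% to 25%.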

Compound 3, a percentage reported as inhibition, at one concentration (the size of the read-out at that concentration, not a potency): 13.4%
Beside the measured number, compound 3's estimate is 3.4 percentage points below it, and the stated range covers the measured number.
By their numbers in this assay, from the lowest: compounds 1, 3 and 2 (each within the scatter of the next).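

Placing fluoro on this ring, para to a large group, gives a number 1 percentage points lower from compound 2 to compound 3 (within the scatter) when it replaces methoxy, and a number 7.7 percentage points higher from compound 1 to compound 3 (within the scatter) when it replaces hydrogen. In this assay this position now holds a third group, and hydrogen, methoxy and fluoro cannot be ranked, since all the steps among them stay within the scatter. No measurement shown here bears on why these numbers lie so close together. As far as these compounds go, whether an amine, a carboxylic acid or a longer chain such as butoxy at this place would move the reading beyond the scatter remains open. Also open is what would happen if the methoxy on the other aromatic ring were replaced, since all the compounds shown keep that group.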